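Swapping the side group of compound 3 for piperazin-1-yl

A few compounds are considered here, and "the series" means these few. Any claim that something is new, unique, unknown or untested is made for them only; others in the source may bear on it.

- Compound 1 `O=C(O)c1cn(C2CC2)c2c(F)c(N3CCCC3)c(F)cc2c1=O`: 120 ug/mL
- Compound 2 `CC1(CN)CCN(c2c(F)cc3c(=O)c(C(=O)O)cn(C4CC4)c3c2F)C1`: 8 ug/mL
- Compound 3 `CNCC1(C)CCN(c2c(F)cc3c(=O)c(C(=O)O)cn(C4CC4)c3c2F)C1`: 8 ug/mL

All three values come from a functional assay on V79 cells (Cricetulus griseus) for cytotoxicity, read by colony formation; on this read-out lower numbers stand for stronger inhibition and higher numbers for weaker inhibition. Compound 3 stands level with compound 2 at the lowest number of the three, and compound 1 has by far the highest.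

The next compound, compound 4 `O=C(O)c1cn(C2CC2)c2c(F)c(N3CCNCC3)c(F)cc2c1=O`, keeps the shared core and changes only the group on the aromatic carbon: piperazin-1-yl in place of 3-methyl-3-((methylamino)methyl)pyrrolidin-1-yl on an aromatic carbon.

Two measured changes at this same place bear on it. They gave a 15-fold lower number from compound 1 to compound 2 (1.18 log units; beyond the scatter) and a 15-fold lower number from compound 1 to compound 3 (1.18 log units; beyond the scatter), both large, so this group can move the number strongly. Adding methyl on the amine nitrogen gave no change at the digits printed from compound 2 to compound 3 (within the scatter), so that detail did not register here.

Among the measured compounds shown here, no measured compound carries piperazin-1-yl, which leaves the size of the step uncertain. Its ring holds an amine nitrogen, as the groups of compound 2 and compound 3 do and the group of compound 1 does not. A moderate move toward a higher number, meaning weaker inhibition, is therefore expected, though not as far as the number of compound 1, which is 120 ug/mL.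

The expected shift is a 3.8-fold higher number from compound 3 to compound 4 (0.57 log units; beyond the scatter).

For compound 4 the estimated value is 30 ug/mL, with an expected range from 10 ug/mL to 100 ug/mL.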

Compound 4, half-maximal inhibitory concentration: 47 ug/mL
Compound 4: middle estimate off by 1.6-fold (0.19 log units), on the low side; low and high end bracket the measured number.
By their numbers in this assay, from the lowest: compounds 2 and 3 (each within the scatter of the next); then compound 4; then compound 1.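

In this assay, this position now shows an intermediate level rather than only two extremes: the change to piperazin-1-yl gives a 2.6-fold lower number from compound 1 to compound 4 (0.41 log units; beyond the scatter) but also a 5.9-fold higher number from compound 3 to compound 4 (0.77 log units; beyond the scatter) and a 5.9-fold higher number from compound 2 to compound 4 (0.77 log units; beyond the scatter). An amine nitrogen in the group therefore does not by itself bring the number down to the level of compound 2 and compound 3, and compound 4, which carries that nitrogen inside a six-membered ring, stays clearly apart from them. No measurement shown explains why these groups differ.

Each step to compound 4 also changes more than one feature of the group, such as ring size or heavy-atom count, so the compounds shown leave open which feature accounts for the differences; 3-aminopyrrolidin-1-yl, with an amine on a five-membered ring but no methyl, would help to separate them. As far as these compounds go, it also remains open whether 4-methylpiperazin-1-yl, with a methyl on the free ring nitrogen, would change the number in this six-membered ring, given that methyl on the side-chain amine gave no change at the digits printed from compound 2 to compound 3 (within the scatter) on the five-membered ring.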